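Swapping Chloro for Fluoro in Growth Hormone Secretagogue Agonists

This account rests on a few compounds, and the source may have more. Where it says the series, first, only, none or still open, it means among the compounds named here.

Measured compounds:
Compound 1 `C[C@@H]1CN(c2ccc(Cl)c(NS(=O)(=O)c3ccc(-c4ccccn4)s3)c2)C[C@H](C)N1`: 39.8 nM
Compound 2 `C[C@@H]1CN(c2ccc(F)c(NS(=O)(=O)c3ccc(-c4ccccn4)s3)c2)C[C@H](C)N1`: 100 nM
Compound 3 `COc1ccc(N2C[C@@H](C)N[C@@H](C)C2)cc1NS(=O)(=O)c1ccc(-c2cccs2)cc1Cl`: 0.794 nM

All three were tested in a functional assay for agonist activity at growth hormone secretagogue receptor type 1 (Homo sapiens), read by FLIPR; a lower number here means that less compound is needed, a higher number that more compound is needed for the effect. Compound 1 and compound 2 share one core and differ in a single place: fluoro in place of chloro on an aromatic carbon. This change gave a 2.5-fold higher number from compound 1 to compound 2 (0.40 log units; beyond the scatter), so the fluoro compound needed somewhat more to reach the same effect.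

Compound 3 is built on another core, and the difference between the two cores is not broken down here. In this assay compound 3 gives 0.794 nM, the lowest number of the three, well beyond the scatter from both compound 1 and compound 2.

Compound 4 `COc1ccc(N2C[C@@H](C)N[C@@H](C)C2)cc1NS(=O)(=O)c1ccc(-c2cccs2)cc1F` has not yet been measured. It differs from compound 3 in one place: fluoro in place of chloro on an aromatic carbon. Within the data shown here, this is the same kind of change as the one from compound 1 to compound 2, though not the same: in compound 1 the changed carbon is para to a 3,5-dimethylpiperazin-1-yl group, whereas in compound 3 it is meta to a thiophen-2-yl group.

Among the measured compounds shown here, for compound 4 in this assay a step of about a 2.5-fold higher number from compound 3 to compound 4 (0.40 log units; beyond the scatter) is expected, resting on the single earlier example, where the same kind of change gave a 2.5-fold higher number from compound 1 to compound 2 (0.40 log units; beyond the scatter). The estimate for compound 4 is therefore 2 nM, expected to fall between 0.6 nM and 6.3 nM.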

Compound 4, half-maximal effective concentration: 2 nM
Compound 4: middle estimate and measured number agree at the digits printed; low and high end bracket the measured number.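

Replacing chloro with fluoro on the core of compound 3 gave a 2.5-fold higher number from compound 3 to compound 4 (0.40 log units; beyond the scatter) in this assay, so here too the fluoro compound needed somewhat more to reach the same effect. The swap therefore behaved alike on both cores, even though the changed carbon has different surroundings in each, and in this small set its effect on the number carried over from one core to the other: the same change on two cores in this assay, a 2.5-fold higher number (0.40 log units; beyond the scatter) from compound 1 to compound 2 and a 2.5-fold higher number (0.40 log units; beyond the scatter) from compound 3 to compound 4, 1.0-fold (0.00 log units) apart, within the scatter of two such steps. Among these compounds, this agreement rests on only two matched pairs in a single assay, so it is a useful sign for this series but not a rule, and it does not show that the step would hold on a further core or explain why the two steps match.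

At the changed carbon, the compounds shown carry only chloro and fluoro, so it remains open how bromo, a methyl group or a nitrile would compare there. From the compounds shown here alone, it also remains open whether the same swap at another carbon of the ring would give a step of similar size, or whether a step of this size would appear in a different kind of assay.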